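Cyano-substituted biaryl variant of the cyclopropane amide series

This account rests on a few compounds, and the source may have more. Where it says the series, first, only, none or still open, it means among the compounds named here.

Compound 3 `CC(C)C[C@H](N)CN(C(=O)[C@@H]1C[C@H]1c1ccccc1)c1ccc(-c2ccsc2)cc1` gives 1200 nM in a functional assay for agonist activity at G protein-coupled receptor 88 (Homo sapiens), read by HTRF and cAMP accumulation (on this read-out higher numbers stand for an effect only at larger amounts of compound and lower numbers for an effect already at smaller amounts), the highest of the three numbers recorded. Compound 2 `CC[C@H](C)[C@H](N)CN(C(=O)[C@@H]1C[C@H]1c1ccc(F)cc1)c1ccc(-c2ccccc2)cc1` gives 600 nM, within the scatter of compound 3, whereas compound 1 `CC(C)C[C@H](N)CCN(C(=O)[C@@H]1C[C@H]1c1ccccc1)c1ccc(-c2ccccc2)cc1` gives 3 nM, a gap that lies well beyond the scatter; compound 1 differs from compound 3 in more than one place, so no single step can be read from it. Compound 4 `CC(C)C[C@H](N)CN(C(=O)[C@@H]1C[C@H]1c1ccccc1)c1ccc(-c2cccc(C#N)c2)cc1` is not yet measured. It differs from compound 3 by 3-cyanophenyl in place of thiophen-3-yl on an aromatic carbon. Going by the values given here, no measured pair isolates this change, so the direction is uncertain; a moderate step toward a lower number is expected, a 3.0-fold lower number from compound 3 to compound 4 (0.48 log units; beyond the scatter). For compound 4 the estimate in this assay is 400 nM, with a range from 80 nM to 2000 nM.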

Compound 4, half-maximal effective concentration: 4500 nM
Compound 4: the middle estimate sits 11-fold (1.05 log units) below what was measured; the measured number lies above the stated range.
By their numbers in this assay, from the lowest: compound 1; then compounds 2 and 3 (each within the scatter of the next); then compound 4.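

Replacing thiophen-3-yl with 3-cyanophenyl on an aromatic carbon para to a large group gives a 3.8-fold higher number from compound 3 to compound 4 (0.57 log units; beyond the scatter) in this assay. Going by these compounds alone, this is the first single-place step, and it shows that this position responds to a change of aromatic group, here toward a higher number. No supporting measurement bears on the reason for this step.

No pair shown separates the nitrile from the change of ring. Also open, as far as these compounds go, is how a carboxylic acid or an amine on the terminal ring would read.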